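Removing a chloro from the benzyl of compound 2

The source may hold more compounds than are shown below. What is called first, only, known or untested is meant among the compounds shown, and "the series" means these compounds.

Three compounds share a core and were tested in a functional assay on ECa-109 cells (Homo sapiens) for antiproliferative activity, read by MTT assay, with a stated time of 72 h; on this read-out higher numbers stand for weaker inhibition and lower numbers for stronger inhibition. Compound 1 `C#CCSc1nc(N/N=C/c2ccc(N(C)C)cc2)c2nnn(Cc3ccccc3)c2n1` gives 31300 nM in this assay. Compound 3 `CCCSc1nc(N/N=C/c2cc(OC)c(OC)c(OC)c2)c2nnn(Cc3ccccc3)c2n1` gives a lower value of 4060 nM. Compound 2 `CCCSc1nc(N/N=C(\C)c2ccccc2O)c2nnn(Cc3ccccc3Cl)c2n1` reaches only a limit of the assay, > 64000 nM, so no number is known for it. That limit is described as the limit of > 64000 nM in this assay, at which 1 of the 3 values shown sits. Compound 4 `CCCSc1nc(N/N=C(\C)c2ccccc2O)c2nnn(Cc3ccccc3)c2n1` has not yet been measured; it differs from compound 2 by hydrogen in place of chloro on an aromatic carbon. Since compound 2 is only a limit, the step that the limit leaves unreadable from compound 2 to compound 4 is expected to be none beyond the scatter, in either direction. Compound 4 is therefore expected near 70000 nM, with a range from 20000 nM to 200000 nM, quite possibly again only a limit.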

Compound 4, half-maximal inhibitory concentration: 11100 nM
Estimate against measurement, compound 4: 6.3-fold (0.80 log units) above; measured number below the stated range.
By their numbers in this assay, from the lowest: compound 3; then compound 4; then compound 1. At a limit, above all of these: compound 2.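

The earlier compounds shown here offered no comparison in a single place. Here, in this assay, going from 2-chlorobenzyl to benzyl gives an at least 5.7-fold lower number from compound 2 to compound 4 (0.76 log units; beyond the scatter), so in this pair the chloro on that aromatic carbon goes with weaker inhibition. Compound 2 is only a limit, so this step is a bound and not a size: the limit of > 64000 nM in this assay, at which 1 of the 4 values shown sits.

Going by these compounds, it remains open whether a fluoro or a bromo on the same carbon would read like chloro or like hydrogen. On these data alone, it is also open whether the same change would count as much with the other groups carried by compound 1 or compound 3.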